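The source may hold more compounds than are shown below. What is called first, only, known or untested is meant among the compounds shown, and "the series" means these compounds.

Measured compounds:
- compound 1, `COc1ccc(/C=C/S(=O)(=O)Cc2ccc(OC)c([N+](=O)[O-])c2)cc1`: 25000 nM
- compound 2, `COc1cc(OC)c(/C=C/SCc2ccc(OC)c(N)c2)c(OC)c1`: 50 nM
- compound 3, `COC(=O)C(F)(F)Nc1cc(CS(=O)(=O)/C=C/c2c(OC)cc(OC)cc2OC)ccc1OC`: 250 nM

In a functional assay on DU-145 cells (Homo sapiens) for cytotoxicity, read by trypan blue exclusion, with a stated time of 96 h (on this read-out lower numbers stand for stronger inhibition and higher numbers for weaker inhibition), compound 1 gives 25000 nM. In this assay compound 2 gives 50 nM, and compound 3 gives 250 nM. Compound 3 thus stands second highest of the three numbers: its nearest neighbour is compound 2, with a lower number by a gap that lies beyond the scatter, and its furthest is compound 1, with a much higher number, also beyond the scatter.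

Compound 4, `COc1cc(OC)c(/C=C/S(=O)(=O)Cc2ccc(OC)c(NC(C(=O)O)c3ccc(Br)cc3)c2)c(OC)c1`, has not yet been measured in this assay. It differs from compound 3 in one place: (4-bromophenyl)(carboxy)methyl in place of difluoro(methoxycarbonyl)methyl on a nitrogen on an aromatic ring. Going by the values given here, no measured pair shows this change, so the account rests on expectation alone. The step from compound 3 is expected to be modest and toward a higher number, as a 2.4-fold higher number from compound 3 to compound 4 (0.38 log units; beyond the scatter), though a result within the scatter of compound 3 would not surprise. Compound 4 is therefore estimated at 600 nM, within a range from 150 nM to 3000 nM.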

Compound 4, half-maximal inhibitory concentration: 300 nM
Compound 4: middle estimate off by 2.0-fold (0.30 log units), on the high side, and the stated range covers the measured number.
By their numbers in this assay, from the lowest: compound 2; then compounds 3 and 4 (each within the scatter of the next); then compound 1.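

On a nitrogen on an aromatic ring, (4-bromophenyl)(carboxy)methyl in place of difluoro(methoxycarbonyl)methyl gives, in this assay, a 1.2-fold higher number from compound 3 to compound 4 (0.08 log units; within the scatter). Going by these compounds alone, the earlier compounds offered no pair differing in one place, so this is the first reading at this position: here, a substituent that brings a six-membered aromatic ring and a hydrogen-bond donor leaves the number within the scatter. No measurement of any property of these groups is at hand to explain this result.

The step exchanges several features at once, so the compounds shown leave open which of them, if any, matters at this nitrogen. A methyl ester in place of the carboxylic acid, or a phenyl without the bromine, would separate these parts, and a simple acetyl group would test a much smaller substituent there.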